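Swapping a sulfur-bearing group for a cyanoguanidine

This account rests on a few compounds, and the source may have more. Where it says the series, first, only, none or still open, it means among the compounds named here.

Compound 1 `C/N=C(\S)NCCCCCn1nc(-c2ccccc2)ccc1=O` is the higher of two measured compounds in a functional assay on the whole organism with Rattus norvegicus as the target, at a dose of 100 mg/kg (on this read-out lower numbers stand for less inhibition and higher numbers for more inhibition at the one dose given (going by the name of the read-out)), where compound 1 gives 68.9%. Among the compounds with values here, compound 2 `C/N=C(/NC#N)N(C)CCCCn1nc(-c2ccccc2)ccc1=O` gives 27% in this assay, and the single measured step, a number 41.9 percentage points lower from compound 1 to compound 2 (beyond the scatter), comes from exchanging a sulfur-bearing group for a cyanoguanidine on the chain. Compound 3 `CN(C)/C(=N/CCCn1nc(-c2ccccc2)ccc1=O)NC#N`, not yet measured, differs from compound 1 by a group of 8 heavy atoms (4 carbon, 4 nitrogen; no ring) in place of a group of 7 heavy atoms (4 carbon, 2 nitrogen, 1 sulfur; no ring), on a saturated chain carbon, three bonds along the chain from an aromatic nitrogen. Within the data shown here, this change likewise brings in a cyanoguanidine, so the one measured step bears directly on it, though the shorter chain of compound 3 has no measured counterpart. A drop of similar size is therefore expected, meaning a step of a number 38.9 percentage points lower from compound 1 to compound 3 (beyond the scatter). For compound 3 the expected inhibition in this assay is 30%, with a range from 10% to 55%.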

Compound 3, a percentage reported as inhibition, in the whole organism at one dose (the size of the read-out at that dose, not a potency): 72.2%
Beside the measured number, compound 3's estimate is 42.2 percentage points below it; measured number above the stated range.
By their numbers in this assay, from the lowest: compound 2; then compounds 1 and 3 (each within the scatter of the next).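

In this assay, a cyanoguanidine at this place does not have to come with a loss of inhibition: the change gives a number 3.3 percentage points higher from compound 1 to compound 3 (within the scatter) and so leaves the reading within the usual spread. The large fall seen earlier, a number 41.9 percentage points lower from compound 1 to compound 2 (beyond the scatter), therefore cannot be pinned on the cyanoguanidine alone, since compound 3 carries one too and goes against any such rule. Nothing measured here explains why these two exchanges end so differently.

As far as these compounds go, compound 2 and compound 3 differ in both chain length and the placing of their methyl groups, so it remains open which of these separates them. Also open, from the compounds shown here alone, is how a longer chain bearing the dimethyl cyanoguanidine, or a urea or simple amine in its place, would behave.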